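A few compounds are considered here, and "the series" means these few. Any claim that something is new, unique, unknown or untested is made for them only; others in the source may bear on it.

In a functional assay on the whole organism (strain Sprague-Dawley) for inhibition, with Rattus norvegicus as the target, with a stated time of 10 min (on this read-out lower numbers stand for an effect already at smaller amounts and higher numbers for an effect only at larger amounts of compound), compound 1 `CCOC(=O)c1cnc(-c2cc([N+](=O)[O-])ccc2OCC)[nH]c1=O` gives 5 mg/kg. Going by the values given here, that is the only number available in this small set, so compound 1 cannot yet be ranked against anything. Two relatives share its core but offer no comparison. The entry for compound 2 `CCOC(=O)c1cnc(-c2cc(N(C)C)ccc2OCC)[nH]c1=O` reads "not determined" (no result reported), and the entry for compound 3 `CCOC(=O)c1cnc(-c2cc(S(=O)(=O)Cl)ccc2OCC)[nH]c1=O` reads "not determined" (no result reported).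

The next compound to be tested is compound 4 `CCOC(=O)c1cnc(-c2cc([N+](=O)[O-])cc([N+](=O)[O-])c2OCC)[nH]c1=O`, which keeps the whole of compound 1 and changes it in one place: nitro in place of hydrogen on an aromatic carbon. This puts a nitro in place of hydrogen on an aromatic carbon, ortho to an ethoxy group and meta to a nitro group.

Among the compounds with values here, no pair of measured compounds differs in one place, so the data give no guide to the size or direction of such a change. The working expectation is therefore no shift beyond the usual scatter. The estimated change is no change at the digits printed from compound 1 to compound 4 (within the scatter). The expected value for compound 4 is 5 mg/kg, with an estimated range from 1.5 mg/kg to 20 mg/kg.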

Compound 4, dose for 50% inhibition: > 50 mg/kg
Compound 4 gave a limit, no number; the forecaster's own chance of this, stated with the estimate: 10%; middle value at least 10-fold (1.00 log units) away from the limit.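

Going by these compounds alone, this is the first comparison in the set between compounds that differ in one place, and it shows that this aromatic carbon is not indifferent to substitution. In this assay, putting a nitro in place of hydrogen, ortho to an ethoxy group and meta to a nitro group, gives an at least 10-fold higher number from compound 1 to compound 4 (1.00 log units; beyond the scatter), so an effect now appears only at larger amounts of compound. The reading for compound 4 is a limit and not a number, so the full size of this step stays unknown: the limit of > 50 mg/kg in this assay, at which 1 of the 4 values shown sits.

A single step cannot show whether this loss belongs to the nitro group itself or would follow any group placed on this carbon. A fluorine atom, a methyl group or an amine at the same place would separate those two readings.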